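The source may hold more compounds than are shown below. What is called first, only, known or untested is meant among the compounds shown, and "the series" means these compounds.

The series shares one core, shown in compound 1 `CC(C)[C@H](NC(=O)COc1cccc2ccccc12)C(=O)N[C@@H](CC(=O)O)C(=O)CSc1nc[nH]n1`, and varies the group on a saturated chain carbon bound to a carbonyl carbon. In a functional assay on Jurkat cells (Homo sapiens) for inhibition (on this read-out lower numbers stand for stronger inhibition and higher numbers for weaker inhibition), compound 1 gives > 200000 nM, which is a limit of the assay and not a number. Compound 2 `CC(C)[C@H](NC(=O)COc1cccc2ccccc12)C(=O)N[C@@H](CC(=O)O)C(=O)COc1ccncn1` likewise sits at a limit in this assay, > 200000 nM. Within the data shown here, compound 3 `CC(C)[C@H](NC(=O)COc1cccc2ccccc12)C(=O)N[C@@H](CC(=O)O)C(=O)COc1cncc2ccccc12` is the only member with a number, giving 166000 nM in this assay. The steps of an at least 1.2-fold lower number from compound 1 to compound 3 (0.08 log units; that floor lies within the scatter) and an at least 1.2-fold lower number from compound 2 to compound 3 (0.08 log units; that floor lies within the scatter) are only floors, set by the limit of > 200000 nM in this assay, at which 2 of the 3 values shown sit, and the step that the two limits leave unreadable from compound 1 to compound 2 is not readable at all. Compound 4 `CC(C)[C@H](NC(=O)COc1cccc2ccccc12)C(=O)N[C@@H](CC(=O)O)C(=O)COc1nccc2ccccc12` is not yet measured; its change from compound 1 is (isoquinolin-1-yl)oxy in place of (1H-1,2,4-triazol-3-yl)sulfanyl on a saturated chain carbon bound to a carbonyl carbon. The nearest measured step, an at least 1.2-fold lower number from compound 1 to compound 3 (0.08 log units; that floor lies within the scatter), carries an (isoquinolin-4-yl)oxy group into the same place, so only a small move, if any, is expected in this assay. Compound 4 is expected near 150000 nM, within 50000 nM to 400000 nM, and a limit remains possible. The expected step is an at least 1.3-fold lower number from compound 1 to compound 4 (0.12 log units; that floor lies within the scatter).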

Compound 4, half-maximal inhibitory concentration: 106000 nM
For compound 4 the middle estimate is 1.4-fold (0.15 log units) above the measured one, and the stated range covers the measured number.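

Among these compounds, compound 4 gives the position, on a saturated chain carbon bound to a carbonyl carbon, a second real number, so a change within the (isoquinolinyl)oxy group can now be sized for the first time in this assay: a 1.6-fold lower number from compound 3 to compound 4 (0.19 log units; within the scatter). Set against the limit compounds, the new value gives only an at least 1.8-fold lower number from compound 1 to compound 4 (0.27 log units; that floor lies within the scatter) and an at least 1.8-fold lower number from compound 2 to compound 4 (0.27 log units; that floor lies within the scatter), so no step in this series yet lies beyond the scatter. Those two steps remain floors because compound 1 and compound 2 are held at a limit of the assay: the limit of > 200000 nM in this assay, at which 2 of the 4 values shown sit.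

Going by these compounds, how far compound 1 and compound 2 truly lie from the two isoquinolinyl compounds stays open. Also open, on these data alone, is whether an amine or a carboxylic acid in this place would move the number beyond the scatter.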